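The source may report more compounds than this note shows. Statements on the series, on what has been measured and on what is new or still open speak of the compounds shown alone.

Measured in a functional assay on Jurkat cells (Homo sapiens) for cytotoxicity, with a stated time of 72 h; a lower number here means that less compound is needed, a higher number that more compound is needed for the effect:
- compound 1 `C=C[C@@](C)(/C=C/c1ccc(O)cc1)CC/C=C(\C)CO` gives > 49000 nM as a limit
- compound 2 `C=C[C@@](C)(/C=C/c1ccc(O)c(C=O)c1)CCC=C(C)C` gives > 49000 nM as a limit

Going by the values given here, compound 2 thus has a limit and no number, and the series so far offers only the limit of > 49000 nM in this assay, at which 2 of the 2 values shown sit, as its reading. Compound 3 `C=C[C@@](C)(/C=C/c1ccc(O)c(/C=C/C(=O)OCC)c1)CCC=C(C)C` follows from compound 2 by one change 2-(ethoxycarbonyl)ethenyl in place of formyl on an aromatic carbon with 2-(ethoxycarbonyl)ethenyl in place of formyl on an aromatic carbon, ortho to a hydroxy group. Among the compounds with values here, no measured step gives a size to work from. The expected step is an at least 1.6-fold lower number from compound 2 to compound 3 (0.21 log units; that floor lies within the scatter) in the direction of less compound needed, and it is expected to be modest. Compound 3 is estimated at 30000 nM within an expected range of 10000 nM to 60000 nM in this assay here.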

Compound 3, half-maximal effective concentration: > 49000 nM
Compound 3 was reported as a limit (the forecaster's own chance of this, stated with the estimate: 55%); middle value at least 1.6-fold (0.21 log units) away from the limit.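

Compound 2 and compound 3 are both reported as limits in this assay, so no step between them can be read: the limit of > 49000 nM in this assay, at which 3 of the 3 values shown sit.

The compounds shown leave open how the formyl and 2-(ethoxycarbonyl)ethenyl compounds compare on a measured number in this assay.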